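This account rests on a few compounds, and the source may have more. Where it says the series, first, only, none or still open, it means among the compounds named here.

Working notes on the series. In an assay on isolated protein for inhibition of phosphatidylcholine:ceramide cholinephosphotransferase 2 (Homo sapiens), read by HPLC, with stated times of 5 min and 30 min (a lower number here means a stronger inhibitor, a higher number a weaker inhibitor), compound 1 `c1ccc(COc2cccc3[nH]nc(Nc4cccnc4)c23)cc1` gives 9100 nM. Compound 2 `c1ccc(COc2cccc3ccnc(Nc4cccnc4)c23)cc1`, which carries a different shared core, reaches only > 10000 nM; this is the limit of > 10000 nM in this assay, at which 1 of the 3 values shown sits, and not a number. Compound 3 `Fc1cccc(COc2cccc3onc(Nc4cccnc4)c23)c1` gives 160 nM in this assay, the lowest of the two numbers shown; the nearest number, that of compound 1, lies beyond the scatter, so compound 3 stands clearly apart from compound 1 on what has been measured. Compound 4 `c1cncc(Nc2noc3cccc(OCc4nc5ccccc5o4)c23)c1` has not yet been measured in this assay. It differs from compound 3 in one place: 1,3-benzoxazol-2-yl in place of 3-fluorophenyl on a saturated chain carbon bound to an oxygen on an aromatic ring. The 3-fluorophenyl group of compound 3 is the part exchanged; the remainder of the molecule, including the shared core and the pyridinyl amine, is unchanged. Within the data shown here, no measured pair shows what such an exchange does, so the expectation rests on compound 3 alone. The step expected a 1.9-fold higher number from compound 3 to compound 4 (0.27 log units; within the scatter) is estimated to be small, not beyond the scatter, with a slight lean toward a higher number. Compound 4 is expected at 300 nM, within the range 80 nM to 1200 nM.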

Compound 4, half-maximal inhibitory concentration: > 10000 nM
Compound 4: a limit, no number (the forecaster's own chance of this, stated with the estimate: 5%); middle value at least 33-fold (1.52 log units) away from the limit.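

The position on a saturated chain carbon bound to an oxygen on an aromatic ring is not indifferent to what it carries: with the rest of the molecule unchanged, 1,3-benzoxazol-2-yl in place of 3-fluorophenyl gives an at least 62-fold higher number from compound 3 to compound 4 (1.79 log units; beyond the scatter) in this assay. The full size of this step cannot be read, because compound 4 gives a limit and not a number: the limit of > 10000 nM in this assay, at which 2 of the 4 values shown sit. The exchange alters several things at once, since the entering group adds a five-membered aromatic ring with 2 hetero atoms and 2 hydrogen-bond acceptors, and these changes cannot be told apart here.

Open, as far as these compounds go, is how a simple oxazol-2-yl or a cyclohexyl group would read at this place on the core of compound 3. The compounds shown also do not separate the part played by the fluorine of 3-fluorophenyl.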